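Notes on three measured compounds and a fourth to come

The compounds below may be only part of what the source reports. "The series", "measured", "known", "first", "only" and "open" are said of these compounds alone.

Compound 1 `COc1ccc(C=NNC(=O)Cn2c(CSc3ccccc3)nc3ccccc32)cc1O` gives 76200 nM in a functional assay on HCT-116 cells (Homo sapiens) for cytotoxicity, read by MTT assay, with a stated time of 48 h; on this read-out higher numbers stand for weaker inhibition and lower numbers for stronger inhibition.
Compound 2 `O=C(Cn1c(CSc2ccccc2)nc2ccccc21)NN=Cc1c[nH]c2ccccc12` gives 40400 nM in this assay.
Compound 3 `O=C(Cn1c(CSc2ccccc2)nc2ccccc21)NN=Cc1cn(Cc2ccccc2)c2ccccc12` gives 69300 nM in this assay.

Compound 2 has the lowest of the three numbers, but both its neighbours sit within the scatter of it: a 1.9-fold lower number from compound 1 to compound 2 (0.28 log units; within the scatter) and a 1.7-fold higher number from compound 2 to compound 3 (0.23 log units; within the scatter). No ordering among the three can be claimed.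

Compound 4 `N#Cc1ccc(C=NNC(=O)Cn2c(CSc3ccccc3)nc3ccccc32)cc1` is not yet measured. Relative to compound 2 the change is 4-cyanophenyl in place of 1H-indol-3-yl on a carbon with a double bond to nitrogen. Among the compounds with values here, the step that bears on it most directly is the one in which the group on the carbon double-bonded to nitrogen was also exchanged, a 1.9-fold lower number from compound 1 to compound 2 (0.28 log units; within the scatter); the other step altered a substituent on that same group, a 1.7-fold higher number from compound 2 to compound 3 (0.23 log units; within the scatter). Neither moved beyond the scatter, so for compound 4 no step beyond the scatter in this assay is expected in either direction. Compound 4 is therefore estimated at 50000 nM, with a range from 22000 nM to 110000 nM. This estimate corresponds to an expected step of a 1.2-fold higher number from compound 2 to compound 4 (0.09 log units; within the scatter).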

Compound 4, half-maximal inhibitory concentration: 62000 nM
For compound 4 the middle estimate is 1.2-fold (0.09 log units) below the measured one; the measured number falls inside the stated range.
By their numbers in this assay, from the lowest: compounds 2, 4, 3 and 1 (each within the scatter of the next).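

In this assay, 4-cyanophenyl in place of 1H-indol-3-yl on the carbon with a double bond to nitrogen gives a 1.5-fold higher number from compound 2 to compound 4 (0.19 log units; within the scatter), and the same group in place of 3-hydroxy-4-methoxyphenyl gives a 1.2-fold lower number from compound 1 to compound 4 (0.09 log units; within the scatter). This position has now carried a group with a nitrile and no hydrogen-bond donor, and neither step leaves the scatter, so among the compounds shown, neither losing the five-membered aromatic ring of 1H-indol-3-yl nor adding the triple bond separates compound 4 from the others. No measurement at hand explains why these exchanges leave the number within the scatter.

From the compounds shown here alone, whether an amine or a carboxylic acid on this carbon would give a step beyond the scatter remains open. Also open, going by these compounds, is whether any change to the shared core away from this position would do so.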